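The compounds below may be only part of what the source reports. "The series", "measured", "known", "first", "only" and "open" are said of these compounds alone.

Measured compounds:
compound 1, `Cc1ccc(-c2ccccc2S(=O)(=O)N2CCC(N3CCC(C)CC3)CC2)cc1`: in a functional assay on DLD-1 cells (Homo sapiens) for antiproliferative activity, read by CellTiter-Glo, with a stated time of 72 h (a lower number here means a stronger inhibitor, a higher number a weaker inhibitor), compound 1 gives 366 nM
compound 2, `CC1CCN(C2CCN(S(=O)(=O)c3ccc(-c4ccccc4F)cc3)CC2)CC1`: in this assay compound 2 gives 5 nM

Of the two numbers recorded so far, compound 2 holds the lower one; compound 1 stands well apart from it, and the gap between the two values lies beyond the usual scatter of repeated measurements. The two compounds differ in more than one place, so their values are simply set side by side here and no single step can be read from them.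

Compound 3, `CCCOc1ccc(S(=O)(=O)N2CCC(N3CCC(C)CC3)CC2)cc1`, has not yet been measured. It differs from compound 2 in one place: propoxy in place of 2-fluorophenyl on an aromatic carbon. The change takes away a ring and puts a short chain in its place. For the measured compounds named here, with no measured step of this kind to lean on, the expectation is a rise in the number from compound 2 to compound 3, beyond the scatter. For compound 3 the estimated value in this assay is 120 nM, with a range from 15 nM to 1000 nM, which corresponds to an expected step of a 24-fold higher number from compound 2 to compound 3 (1.38 log units; beyond the scatter).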

Compound 3, half-maximal inhibitory concentration: 452 nM
Compound 3: the middle estimate sits 3.8-fold (0.58 log units) below what was measured; measured number inside the range.
By their numbers in this assay, from the lowest: compound 2; then compounds 1 and 3 (each within the scatter of the next).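

In this assay, for the compounds shown here, the change to propoxy in place of 2-fluorophenyl, on an aromatic carbon para to a large group, brings a 90-fold higher number from compound 2 to compound 3 (1.96 log units; beyond the scatter) and gives the first step here that can be read at a single place. It shows that this position is sensitive to what it carries: the group with the six-membered aromatic ring goes with the low number, and the shorter chain with no ring goes with a far higher one. Nothing available bears on what lies behind this step.

The compounds shown leave open whether an unsubstituted phenyl at this place would keep the low number, and so whether the fluorine on the ring counts at all. They also leave open how a methoxy, a longer alkoxy chain or an amine would compare with the two groups seen so far.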